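Amide cap swap on the sulfonyl tetrahydronaphthalene series

A few compounds are considered here, and "the series" means these few. Any claim that something is new, unique, unknown or untested is made for them only; others in the source may bear on it.

Going by the values given here, compound 2 `O=C(NC[C@@H]1CCCc2cc(S(=O)(=O)c3cccc(F)c3)ccc21)[C@H]1CCCN1` holds the lowest number measured so far in an assay on isolated protein for displacement of a labelled ligand from 5-hydroxytryptamine receptor 6 (Homo sapiens) (a lower number here means a stronger inhibitor, a higher number a weaker inhibitor), giving 0.631 nM. Its nearest neighbour, compound 1 `NC[C@@H]1CCCc2cc(S(=O)(=O)c3cn[nH]c3)ccc21`, gives 2 nM in this assay, a gap beyond the scatter; the two differ in more than one place, so only the two values themselves are compared here. Compound 3 `CC(C)(C)C(=O)NC[C@@H]1CCCc2cc(S(=O)(=O)c3cccc(F)c3)ccc21` is the next member to be measured. Its difference from compound 2 is tert-butyl in place of pyrrolidin-2-yl on a carbonyl carbon. Among the compounds with values here, with no step of this kind yet measured, a moderate loss beyond the scatter is expected for a 4.8-fold higher number from compound 2 to compound 3 (0.68 log units; beyond the scatter). Compound 3 is therefore estimated at 3 nM in this assay, within a range of 0.8 nM to 12 nM.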

Compound 3, inhibition constant: 3.98 nM
The estimate for compound 3 lay 1.3-fold (0.12 log units) below the measured number; the range from low to high includes it.
By their numbers in this assay, from the lowest: compound 2; then compounds 1 and 3 (each within the scatter of the next).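

In this assay the cap on the carbonyl carbon now has its first one-place step, a 6.3-fold higher number from compound 2 to compound 3 (0.80 log units; beyond the scatter), so this position does respond to the change. The change removes the ring, the hydrogen-bond donor and acceptor, and the defined stereocentre of pyrrolidin-2-yl together, and this single step cannot separate them. No measurement here accounts for the difference.

Open, on these data alone, is whether an acyclic cap carrying an amine, such as aminomethyl, would recover the value of compound 2. Also open, as far as these compounds go, is whether the opposite stereocentre on pyrrolidin-2-yl would give the same number.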